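The compounds below may be only part of what the source reports. "The series", "measured", "known", "first", "only" and "open" are said of these compounds alone.

Compound 1, `Cn1cc(CN2CCC[C@H](OCc3cc(Cl)cc(Cl)c3)[C@@H]2c2ccccc2)cn1`: 110000 nM
Compound 2, `O=C(O)c1cncc(CN2CCC[C@H](O[C@H](CO)c3cc(Cl)cc(Cl)c3)[C@@H]2c2ccccc2)c1`: 34000 nM

Of the compounds shown here, two have been tested in an assay on isolated protein for activation of cGMP-dependent protein kinase 1 (Homo sapiens), read by ADP-Glo, with stated times of 120 min and 40 min; a higher number here means that more compound is needed for the effect, a lower number that less compound is needed. Compound 2 gives 34000 nM, the lower of the two numbers, while compound 1 gives 110000 nM, a gap beyond the usual scatter. Compound 3, `O=C(O)c1cncc(CN2CCC[C@H](OCc3cc(Cl)cc(Cl)c3)[C@@H]2c2ccccc2)c1`, differs from compound 2 in one place: hydrogen in place of hydroxymethyl on a saturated chain carbon bound to an aromatic carbon and an oxygen on a saturated carbon. Among the compounds with values here, compound 1 also carries the 3,5-dichlorobenzyl group but differs from compound 2 elsewhere as well, so no single measured step shows what this change alone does. Removing the hydroxymethyl is expected to cost a modest amount: a 1.8-fold higher number from compound 2 to compound 3 (0.25 log units; within the scatter). Compound 3 is therefore estimated at 60000 nM, most likely between 20000 nM and 180000 nM.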

Compound 3, half-maximal effective concentration: 117000 nM
For compound 3 the middle estimate is 2.0-fold (0.29 log units) below the measured one; the measured number falls inside the stated range.
By their numbers in this assay, from the lowest: compound 2; then compounds 1 and 3 (each within the scatter of the next).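

In this assay, within the data shown here, the hydroxymethyl on this saturated chain carbon matters: replacing it with hydrogen gives a 3.4-fold higher number from compound 2 to compound 3 (0.54 log units; beyond the scatter), a step seen here for the first time. With the 3,5-dichlorobenzyl group in place, swapping the 1-methyl-1H-pyrazol-4-yl for 5-carboxypyridin-3-yl gives a 1.1-fold higher number from compound 1 to compound 3 (0.03 log units; within the scatter), so these two groups cannot be told apart. Nothing available explains either result.

On these data alone, whether a plain methyl or a longer chain such as hydroxyethyl would serve as well as hydroxymethyl stays open. So does whether hydroxymethyl would have the same effect alongside the 1-methyl-1H-pyrazol-4-yl group.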